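From a Neopentyl Amide to a Methyl Carbamate

The source may hold more compounds than are shown below. What is called first, only, known or untested is meant among the compounds shown, and "the series" means these compounds.

Of the compounds shown here, three so far have a number in a physicochemical assay for lipophilicity, at pH 7.4; a higher number here means a more lipophilic compound, a lower number a more polar compound. Compound 1 `Cc1cc(C(=O)O)nn1Cc1cc(Br)ccc1OCc1ccccc1` gives 1.2. Compound 2 `Cc1cc(C(=O)NN2CCCCC2)nn1Cc1cc(Cl)ccc1OCC(C)C` gives 3.3. For the measured compounds named here, compound 3 `Cc1cc(NC(=O)CC(C)(C)C)nn1Cc1cc(Cl)ccc1OCc1ccccc1` reaches only a limit of this assay, reported as > 3.7; it is the single compound sitting at the limit of > 3.7 in this assay, at which 1 of the 3 values shown sits. Compound 4 `COC(=O)Nc1cc(C)n(Cc2cc(Cl)ccc2OCc2ccccc2)n1` has not yet been measured. It differs from compound 3 in one place: methoxy in place of neopentyl on a carbonyl carbon. The neopentyl group leaves and a smaller methoxy group, bringing one hydrogen-bond acceptor, takes its place on the carbonyl carbon. Going by the values given here, no measured pair shows this exact change, so the expected step of a number at least 0.30 log units lower from compound 3 to compound 4 (that floor lies within the scatter) is a drop in lipophilicity beyond the usual scatter. Compound 4 is estimated at 3.4, within a range from 2.7 to 4.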

Compound 4, distribution coefficient: > 3.7
Compound 4 gave a limit, no number; the forecaster's own chance of this, stated with the estimate: 20%; middle value at least 0.30 log units from the limit.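

In this assay, for the compounds shown here, compound 4, like compound 3, reaches only a limit, so no step between the two can be read: the limit of > 3.7 in this assay, at which 2 of the 4 values shown sit.

The compounds shown leave open how far, and in which direction, methoxy in place of neopentyl on a carbonyl carbon shifts the read-out.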